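Ester in Place of Amide on the Shared Thiophene Core

A few compounds are considered here, and "the series" means these few. Any claim that something is new, unique, unknown or untested is made for them only; others in the source may bear on it.

Compound 2 `Nc1sc(-c2ccc(Cl)cc2)c(-c2ccc(Cl)cc2)c1C(=O)NC1CCC(O)CC1` is examined in a functional assay on PC-3 cells (Homo sapiens) for inhibition, read by sulforhodamine B assay, with a stated time of 72 h (a higher number here means a weaker inhibitor, a lower number a stronger inhibitor), where compound 2 gives 5670 nM, the lowest of the two numbers available. Its neighbour compound 1 `CC1CN(C(=O)c2c(N)sc(-c3ccc(Cl)cc3)c2-c2ccc(Cl)cc2)CCN1` gives 7210 nM in this assay, and the step of a 1.3-fold lower number from compound 1 to compound 2 (0.10 log units; within the scatter) stays within the scatter. A third member, compound 3 `CCN(CC)CCNC(=O)Nc1sc(-c2ccc(Cl)cc2)c(-c2ccc(Cl)cc2)c1C(=O)NC1CC1`, carries as its result in this assay only "not determined" (no result reported), so compound 3 contributes no number.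

Compound 4 `COC(=O)c1c(N)sc(-c2ccc(Cl)cc2)c1-c1ccc(Cl)cc1` differs from compound 2 by methoxy in place of (4-hydroxycyclohexyl)amino on a carbonyl carbon. Among the measured compounds shown here, no measured step covers this exchange: the only step recorded, from a 3-methylpiperazin-1-yl to a (4-hydroxycyclohexyl)amino group, is within the scatter, and both of those groups remain attached through nitrogen, whereas methoxy is not. The change removes the ring and both hydrogen-bond donors of the leaving group. With nothing in the series to anchor a direction, the estimate for compound 4 is kept close to compound 2, with a slight lean toward a higher number and a wide range.

The expected step of a 1.6-fold higher number from compound 2 to compound 4 (0.20 log units; within the scatter) is therefore small. Compound 4 is estimated at 9000 nM, within 3000 nM to 30000 nM.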

Compound 4, half-maximal inhibitory concentration: 2780 nM
The estimate for compound 4 lay 3.2-fold (0.51 log units) above the measured number; the whole stated range lies above it.
By their numbers in this assay, from the lowest: compound 4; then compounds 2 and 1 (each within the scatter of the next).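

In this assay the change to methoxy on the carbonyl carbon gives a 2.0-fold lower number from compound 2 to compound 4 (0.31 log units; beyond the scatter) when (4-hydroxycyclohexyl)amino leaves and a 2.6-fold lower number from compound 1 to compound 4 (0.41 log units; beyond the scatter) when 3-methylpiperazin-1-yl leaves. Among the compounds shown here, these modest steps are the first beyond the scatter, and they show that this position needs neither attachment through nitrogen nor the ring and hydrogen-bond donors of (4-hydroxycyclohexyl)amino for the lower number seen here. Nothing at hand gives a reason for this shift.

On these data alone, it remains open whether the lower number goes with the oxygen attachment or with the smaller group as such. An ethyl ester, a carboxylic acid or a methylamino group on the same carbonyl carbon would help to separate these two readings.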